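A few compounds are considered here, and "the series" means these few. Any claim that something is new, unique, unknown or untested is made for them only; others in the source may bear on it.

In a functional assay on U-937 cells (Homo sapiens) for antiproliferative activity, read by MTT assay, with a stated time of 72 h (on this read-out higher numbers stand for weaker inhibition and lower numbers for stronger inhibition), compound 1 (`Cc1ccc(-c2noc(CCCCCCC(=O)NO)n2)cc1`) gives 1360 nM and compound 2 (`O=C(CCCCCCc1nc(-c2ccccc2Cl)no1)NO`) gives 750 nM while compound 3 (`Cc1ccc(-c2noc(CCCCCCC(=O)Nc3ccccc3N)n2)cc1`) gives 460 nM on the same read-out. Compound 3 thus lies within the scatter of compound 2 and clearly under compound 1. Compound 4 (`Nc1ccccc1NC(=O)CCCCCCc1nc(-c2ccc([N+](=O)[O-])cc2)no1`) differs from compound 3 by nitro in place of methyl on an aromatic carbon. For the measured compounds named here, only one measured step changes the substituent on that aromatic ring (a 1.8-fold lower number from compound 1 to compound 2 (0.26 log units; within the scatter)) and it stays within the scatter, while the modest step at the amide-type nitrogen (a 3.0-fold lower number from compound 1 to compound 3 (0.47 log units; beyond the scatter)) does not bear on this change. No step beyond the scatter is therefore expected in this assay in either direction. The expected step is a 1.0-fold higher number from compound 3 to compound 4 (0.02 log units; within the scatter) and it is estimated to stay within the scatter. For compound 4 the estimated value is 480 nM with an expected range of 170 nM to 1350 nM in this measurement.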

Compound 4, half-maximal inhibitory concentration: 10300 nM
For compound 4 the middle estimate is 21-fold (1.33 log units) below the measured one; the whole stated range lies below it.
By their numbers in this assay, from the lowest: compounds 3, 2 and 1 (each within the scatter of the next, the first and the last beyond it); then compound 4.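

On this read-out, the place para to a large group on the six-membered aromatic ring proves sensitive to its substituent: nitro in place of methyl gives a 22-fold higher number from compound 3 to compound 4 (1.35 log units; beyond the scatter) and is a large step, which the earlier change on that ring, at a 1.8-fold lower number from compound 1 to compound 2 (0.26 log units; within the scatter) and within the scatter, gave no sign of. Nothing measured here accounts for this step. On these data alone, it remains open whether an amine or a methoxy group at this place would stay near compound 3, and whether nitro would give a similar step with hydroxy on the amide-type nitrogen, as in compound 1.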